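Chloro in place of bromo on the aromatic ring of compound 3

This account rests on a few compounds, and the source may have more. Where it says the series, first, only, none or still open, it means among the compounds named here.

Measured so far in a functional assay on RAW264.7 cells (Mus musculus) for inhibition, with a stated time of 30 min; a higher number here means a weaker inhibitor, a lower number a stronger inhibitor:
compound 1, `C=C1C(=O)OC[C@@H]1CCOC(=O)Nc1ccc(CCCC)cc1`, 1230 nM
compound 2, `C=C1C(=O)OC[C@@H]1CCOC(=O)Nc1ccccc1`, 780 nM
compound 3, `C=C1C(=O)OC[C@@H]1CCOC(=O)Nc1ccc(Br)cc1`, 720 nM

Compound 3 gives the lowest of the three numbers in this assay, but the steps of a 1.7-fold lower number from compound 1 to compound 3 (0.23 log units; within the scatter) and a 1.1-fold lower number from compound 2 to compound 3 (0.03 log units; within the scatter) are both within the scatter, so the three compounds are not separated by these data. The step of a 1.6-fold lower number from compound 1 to compound 2 (0.20 log units; within the scatter) is likewise within the scatter: removing the butyl group has not moved the number in any useful way.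

Compound 4, `C=C1C(=O)OC[C@@H]1CCOC(=O)Nc1ccc(Cl)cc1`, carries the change (chloro in place of bromo on an aromatic carbon). Among the compounds with values here, no step between two halogens has been measured in this set. Within the data shown here, the step that bears most closely on it is a 1.1-fold lower number from compound 2 to compound 3 (0.03 log units; within the scatter), where putting bromo onto the unsubstituted ring of compound 2 left the number essentially where it was; the exchange of one halogen for another is a smaller change than that, and no step in the set shows a substituent on this ring moving the number beyond the scatter. The expectation for compound 4 in this assay is therefore a step of a 1.0-fold higher number from compound 3 to compound 4 (0.02 log units; within the scatter), that is, no change beyond the scatter. Compound 4 is estimated at 750 nM, with a range from 400 nM to 1400 nM.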

Compound 4, half-maximal inhibitory concentration: 1070 nM
The estimate for compound 4 lay 1.4-fold (0.15 log units) below the measured number; low and high end bracket the measured number.
By their numbers in this assay, from the lowest: compounds 3, 2, 4 and 1 (each within the scatter of the next).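

In this assay, within the data shown here, this is the first exchange of one halogen for another on an aromatic carbon para to a large group, and it gives a 1.5-fold higher number from compound 3 to compound 4 (0.17 log units; within the scatter); the two further steps onto chloro, a 1.4-fold higher number from compound 2 to compound 4 (0.14 log units; within the scatter) and a 1.1-fold lower number from compound 1 to compound 4 (0.06 log units; within the scatter), also lie within the scatter. With hydrogen, bromo, chloro and butyl now all compared at this one place, none of the steps among the four compounds lies beyond the scatter, so neither the halogen exchange nor any other change at this carbon separates these compounds in this assay. No measurement at hand bears on these steps or offers an account of them.

Going by these compounds, whether an amine, a carboxylic acid or a chain longer than butyl at this carbon would give a step beyond the scatter remains open. The compounds shown also share one core and vary only at this place, so they leave open how this assay responds to a change anywhere else in the structure.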